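The compounds below may be only part of what the source reports. "The series", "measured", "known", "first", "only" and "open" are said of these compounds alone.

Measured in an ADME assay on microsomes (Homo sapiens) for metabolic stability; on this read-out higher numbers stand for fast clearance and lower numbers for slow clearance:
- Compound 1 `CNC(=O)[C@@H]1CCCN1S(=O)(=O)c1cccc(COc2cccc3c(C(F)(F)F)cc(C)nc23)c1`: 50 mL/min/kg
- Compound 2 `Cc1cc(C(F)(F)F)c2cccc(OCc3c(Cl)ccc(S(=O)(=O)N4CCC[C@H]4CO)c3Cl)c2n1`: 250 mL/min/kg

Compound 2 holds the higher of the two numbers, and its gap to compound 1 lies beyond the scatter. Compound 3 `Cc1cc(C(F)(F)F)c2cccc(OCc3c(Cl)ccc(S(=O)(=O)N4CCC(CCO)CC4)c3Cl)c2n1` has not yet been measured. It carries 4-(2-hydroxyethyl)piperidin-1-yl in place of 2-(hydroxymethyl)pyrrolidin-1-yl on a sulfonyl sulfur. Among the compounds with values here, no measured pair shows what such an exchange does, so no step beyond the scatter is expected in this assay. The expected change is a 1.3-fold lower number from compound 2 to compound 3 (0.10 log units; within the scatter). For compound 3 the estimated clearance is 200 mL/min/kg, with an expected range of 90 mL/min/kg to 400 mL/min/kg.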

Compound 3, clearance: 367 mL/min/kg
For compound 3 the middle estimate is 1.8-fold (0.26 log units) below the measured one; low and high end bracket the measured number.
By their numbers in this assay, from the lowest: compound 1; then compounds 2 and 3 (each within the scatter of the next).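

In this assay the exchange of 2-(hydroxymethyl)pyrrolidin-1-yl for 4-(2-hydroxyethyl)piperidin-1-yl on a sulfonyl sulfur gives a 1.5-fold higher number from compound 2 to compound 3 (0.17 log units; within the scatter) and so stays within the scatter. At this position, then, the six-membered ring with its longer hydroxyl-bearing chain and no defined stereocentre reads alike with the five-membered ring, at least for this pair. Nothing measured here gives a reason for this result. Going by these compounds, whether an amine or a carboxylic acid in place of the hydroxyl on that chain would read differently in this assay remains open.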